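Notes: 1H-pyrazol-1-yl for 4-methyl-1H-imidazol-1-yl

A few compounds are considered here, and "the series" means these few. Any claim that something is new, unique, unknown or untested is made for them only; others in the source may bear on it.

Measured so far in a functional assay on HUVEC cells (Homo sapiens), read by scintillation counting and thymidine incorporation, with a stated time of 24 h; on this read-out lower numbers stand for stronger inhibition and higher numbers for weaker inhibition:
- compound 1 `CCC(C)n1ncn(-c2ccc(N3CCN(c4ccc(OC[C@@H]5CO[C@@](Cn6cnc(C(F)(F)F)n6)(c6ccc(Cl)cc6Cl)O5)cc4)CC3)cc2)c1=O` gives 270 nM
- compound 2 `CCC(C)n1ncn(-c2ccc(N3CCN(c4ccc(OC[C@@H]5CO[C@@](Cn6ccnc6C)(c6ccc(Cl)cc6Cl)O5)cc4)CC3)cc2)c1=O` gives 173 nM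
- compound 3 `CCC(C)n1ncn(-c2ccc(N3CCN(c4ccc(OC[C@@H]5CO[C@@](Cn6cnc(C)c6)(c6ccc(Cl)cc6Cl)O5)cc4)CC3)cc2)c1=O` gives 102 nM

Compound 3 cannot be separated from its nearest neighbour (a 1.7-fold lower number from compound 2 to compound 3 (0.23 log units; within the scatter)) but stands clear of the remaining compound (a 2.6-fold lower number from compound 1 to compound 3 (0.42 log units; beyond the scatter)). Compound 4 `CCC(C)n1ncn(-c2ccc(N3CCN(c4ccc(OC[C@@H]5CO[C@@](Cn6cccn6)(c6ccc(Cl)cc6Cl)O5)cc4)CC3)cc2)c1=O` carries 1H-pyrazol-1-yl in place of 4-methyl-1H-imidazol-1-yl on a saturated chain carbon bound to a saturated ring carbon. All measured steps exchange the group at this same place, so all bear on the change. The third of them (a 1.6-fold lower number from compound 1 to compound 2 (0.19 log units; within the scatter)) also stays small. Among the measured compounds shown here, none of them tests a pyrazole, so no direct precedent exists. For the measured compounds named here, the only clear departure from compound 3 is compound 1 (270 nM), and it lies upward, so a small move to a higher number is expected. The estimated size of the move is a 1.7-fold higher number from compound 3 to compound 4 (0.22 log units; within the scatter) in this assay (a step that may not clear the scatter). The estimate for compound 4 is 170 nM (expected range 70 nM to 420 nM).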

Compound 4, half-maximal inhibitory concentration: 307 nM
Compound 4: middle estimate off by 1.8-fold (0.26 log units), on the low side; the range from low to high includes it.
By their numbers in this assay, from the lowest: compounds 3, 2, 1 and 4 (each within the scatter of the next, the first and the last beyond it).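

In this assay, among the compounds shown here, the first step beyond the scatter that keeps a five-membered aromatic ring with 2 hetero atoms at this place is (a 3.0-fold higher number from compound 3 to compound 4 (0.48 log units; beyond the scatter)): the exchange leaves the counted hydrogen-bond donors, acceptors and charge unchanged and removes a single heavy atom, yet the read-out still separates the two groups. 1H-pyrazol-1-yl cannot be separated from either 2-methyl-1H-imidazol-1-yl (a 1.8-fold higher number from compound 2 to compound 4 (0.25 log units; within the scatter)) or 3-(trifluoromethyl)-1H-1,2,4-triazol-1-yl (a 1.1-fold higher number from compound 1 to compound 4 (0.06 log units; within the scatter)), so compound 3 stands clear of compound 1 and compound 4, while compound 2 stands clear of none. Nothing available accounts for the step.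

The step changes both the methyl and the arrangement of the ring atoms, so it leaves open which of them matters. Unsubstituted 1H-imidazol-1-yl would separate the two, and a ring carrying an amine or a carboxylic acid at this place remains untested in these compounds.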